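The compounds below may be only part of what the source reports. "The series", "measured", "known", "first", "only" and "open" are said of these compounds alone.

Measured so far in a functional assay on HCT-116 cells (Homo sapiens) for cytotoxicity; on this read-out lower numbers stand for stronger inhibition and higher numbers for weaker inhibition:
- compound 1, `COc1ccc(C2=C(c3ccccc3)C(=O)N3CCCC3C2)cc1`, gives 390 nM
- compound 2, `COc1ccc(C2=C(c3ccco3)C(=O)N3CCCC3C2)cc1`, gives 6000 nM
- compound 3, `CSc1ccc(C2=C(c3ccccc3)C(=O)N3CCCC3C2)cc1`, gives 1000 nM

Compound 3 stands second highest of the three numbers in this assay. Its nearest neighbour is compound 1, with a 2.6-fold higher number from compound 1 to compound 3 (0.41 log units; beyond the scatter); its furthest is compound 2, whose number is higher still. The step from compound 1 to compound 2, a 15-fold higher number from compound 1 to compound 2 (1.19 log units; beyond the scatter), shows that swapping the phenyl on the double-bonded ring carbon for a five-membered heteroaryl cost a great deal of activity in this series.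

Compound 4, `CSc1ccc(C2=C(c3ccsc3)C(=O)N3CCCC3C2)cc1`, has not yet been measured. It differs from compound 3 in one place: thiophen-3-yl in place of phenyl on a double-bonded ring carbon. Going by the values given here, no measured step swaps phenyl for thiophen-3-yl, so the only guide is the step from compound 1 to compound 2, which also replaced phenyl with a five-membered heteroaryl at the same ring position and was large. Among the compounds with values here, a loss is therefore expected, though its size is uncertain because only one such step, a 15-fold higher number from compound 1 to compound 2 (1.19 log units; beyond the scatter), exists and it involved a different heteroaryl.

Compound 4 is estimated at 4000 nM in this assay, within a range of 1500 nM to 12000 nM. This estimate means an expected step of a 4.0-fold higher number from compound 3 to compound 4 (0.60 log units; beyond the scatter).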

Compound 4, half-maximal inhibitory concentration: 600 nM
For compound 4 the middle estimate is 6.7-fold (0.82 log units) above the measured one, and the stated range ends above it.
By their numbers in this assay, from the lowest: compounds 1, 4 and 3 (each within the scatter of the next, the first and the last beyond it); then compound 2.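

In this assay, the step of a 1.7-fold lower number from compound 3 to compound 4 (0.22 log units; within the scatter) shows that this double-bonded ring carbon can carry thiophen-3-yl in place of phenyl with no change beyond the scatter, so a six-membered carbon ring is not required here, at least with the 4-(methylsulfanyl)phenyl group as its neighbour. The earlier step of a 15-fold higher number from compound 1 to compound 2 (1.19 log units; beyond the scatter) suggested that leaving phenyl for a five-membered aromatic ring was costly, but the new result shows that this does not hold for every such ring: compound 4 goes against that reading. No measurement on hand explains why thiophen-3-yl is tolerated here while furan-2-yl brought a large loss in the methoxy compounds.

As far as these compounds go, the two heteroaryl steps also start from different compounds, so it remains open whether the large loss belongs to furan-2-yl itself or depends on the methoxy group elsewhere on the molecule. The compounds shown also leave open how thiophen-2-yl, furan-3-yl or a pyridine ring would behave on this carbon, and whether thiophen-3-yl would be tolerated alongside methoxy in place of methylsulfanyl.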